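The source may report more compounds than this note shows. Statements on the series, on what has been measured and on what is new or still open speak of the compounds shown alone.

Notes on the series. In a functional assay on the whole organism (strain albino) for inhibition, with Rattus norvegicus as the target, read by paw edema, with stated times of 30 min and 5 h, at a dose of 100 mg/kg by the oral route (on this read-out lower numbers stand for less inhibition and higher numbers for more inhibition at the one dose given (going by the name of the read-out)), compound 1 `CC(=O)c1ccc(OCC(=O)Nc2ccc(C(=O)/C=C/c3ccc(Cl)cc3)cc2)cc1` gives 55%, compound 2 `COc1ccc(/C=C/C(=O)c2ccc(NC(=O)COc3ccc(C(C)=O)cc3)cc2)cc1` gives 30%, and compound 3 `CC(=O)c1ccc(OCC(=O)Nc2ccc(C(=O)/C=C/c3ccco3)cc2)cc1` gives 36%. Compound 3 stands beyond the scatter below compound 1, by a number 19 percentage points lower from compound 1 to compound 3 (beyond the scatter); the other step to it, a number 6 percentage points higher from compound 2 to compound 3 (within the scatter), is within the scatter, so those two values cannot be ordered. The remaining measured step, a number 25 percentage points lower from compound 1 to compound 2 (beyond the scatter), also concerns the group on the double-bonded chain carbon. Compound 4 `C/C(=N/O)c1ccc(OCC(=O)Nc2ccc(C(=O)/C=C/c3ccco3)cc2)cc1` differs from compound 3 by a group of 4 heavy atoms (2 carbon, 1 nitrogen, 1 oxygen; no ring) in place of a group of 3 heavy atoms (2 carbon, 1 oxygen; no ring), on an aromatic carbon. Within the data shown here, all three measured steps alter the far end of the chain; none touches the acetyl, so no measured step bears on this change, and nothing in the data points to a step beyond the scatter in this assay. Compound 4 is therefore estimated at 36%, with a range from 20% to 52%. The expected step of no change at the digits printed from compound 3 to compound 4 (within the scatter) is within the scatter.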

Compound 4, a percentage reported as inhibition, in the whole organism at one dose (the size of the read-out at that dose, not a potency): 42%
Estimate against measurement, compound 4: 6 percentage points below; the measured number falls inside the stated range.
By their numbers in this assay, from the lowest: compounds 2, 3 and 4 (each within the scatter of the next, the first and the last beyond it); then compound 1.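

Among these compounds, this is the first reading at the acetyl position, on an aromatic carbon para to a large group, since all earlier steps altered the far end of the chain. In this assay, among the compounds shown here, the exchange of acetyl for the group of 4 heavy atoms, which adds a hydrogen-bond donor and a hydrogen-bond acceptor, gives a number 6 percentage points higher from compound 3 to compound 4 (within the scatter) and so, with furan-2-yl at the far end, no step that can be told from the scatter. No measurement at hand accounts for this result.

On these data alone, whether the same exchange reads alike with the 4-chlorophenyl group of compound 1 at the far end stays open. Also open, as far as these compounds go, is how an amine or a carboxylic acid would read in place of the acetyl at this position.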